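A few compounds are considered here, and "the series" means these few. Any claim that something is new, unique, unknown or untested is made for them only; others in the source may bear on it.

For the measured compounds named here, in an ADME assay on microsomes from liver (Mus musculus) for metabolic stability, read by LC-MS, using NADPH, tested at 1 uM (a higher number here means faster removal of the compound, a lower number slower removal), compound 1 `N#Cc1cnc(NC(=O)CCCOc2ccccc2)s1` gives 114 mL.min-1.g-1 and compound 2 `O=C(CCCOc1ccccc1)Nc1ncc(Cl)s1` gives 814 mL.min-1.g-1, so compound 1 holds the lower of the two numbers measured so far. Compound 3 `N#Cc1cnc(NC(=O)CCCOc2cccc(Cl)c2)s1` keeps the cyano group of compound 1 and gains a chloro in place of hydrogen on an aromatic carbon. Put simply, phenyl becomes 3-chlorophenyl.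

Going by the values given here, only one measured step bears on this change. With chloro in place of cyano on an aromatic carbon, the data show a 7.1-fold higher number from compound 1 to compound 2 (0.85 log units; beyond the scatter). That step also brings in a chloro, but it does so at a different place in the molecule and replaces cyano rather than hydrogen. It is therefore a weak guide, offering a possible direction more than a size. A smaller move in the same upward direction seems the reasonable expectation, and it may not rise beyond the scatter. The expected change is a 1.5-fold higher number from compound 1 to compound 3 (0.17 log units; within the scatter). For compound 3 the estimated value is 170 mL.min-1.g-1, with an expected range from 80 mL.min-1.g-1 to 400 mL.min-1.g-1.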

Compound 3, intrinsic clearance in microsomes: 224 mL.min-1.g-1
Estimate against measurement, compound 3: 1.3-fold (0.12 log units) below; measured number inside the range.
By their numbers in this assay, from the lowest: compounds 1 and 3 (each within the scatter of the next); then compound 2.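

In this assay, changing phenyl to 3-chlorophenyl gives a 2.0-fold higher number from compound 1 to compound 3 (0.29 log units; within the scatter), so at this aromatic carbon the added chloro makes no difference that can be told apart from repeat measurements. The earlier swap of cyano for chloro at another place in the molecule gave a 7.1-fold higher number from compound 1 to compound 2 (0.85 log units; beyond the scatter), which lies beyond the scatter, so across these three compounds, bringing in a chloro does not have one fixed outcome: the result depends on where it goes and what it replaces. No measurement shown here explains why the two steps differ.

The compounds shown leave open whether a fluoro, a methoxy or an amine at this same carbon would also stay within the scatter, and whether a chloro on another carbon of that six-membered ring would do so. As far as these compounds go, it also remains open whether the 3-chlorophenyl change would give a similar result on compound 2, which has chloro in place of cyano, or on an analogue with a longer chain.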